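Adding a Second Methoxy Where No Compound Yet Inhibits

This account rests on a few compounds, and the source may have more. Where it says the series, first, only, none or still open, it means among the compounds named here.

Three compounds sharing one core were tested in a functional assay on Caco-2 cells (Homo sapiens) for antiproliferative activity, read by MTT assay, with a stated time of 24 h; on this read-out lower numbers stand for stronger inhibition and higher numbers for weaker inhibition. Compound 1 `COc1ccc(C2CC(c3ccc(Cl)cc3)=NN2c2ccc(-c3ccccc3)nn2)c(OC)c1` gives only the limit of the assay, > 100000 nM. Compound 2 `COc1ccc(C2=NN(c3ccc(-c4ccccc4)nn3)C(c3ccccc3)C2)cc1` likewise gives only the limit, > 100000 nM. Compound 3 `COc1ccc(C2=NN(c3ccc(-c4ccccc4)nn3)C(c3ccc(OC)cc3)C2)cc1` also gives only the limit, > 100000 nM. Going by the values given here, the single comparable step, a step that the two limits leave unreadable from compound 2 to compound 3, has no readable size because the limit of > 100000 nM in this assay, at which 3 of the 3 values shown sit, holds every value at the same point. Compound 3 therefore stands indistinguishable from compound 1 and compound 2 on these numbers.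

Compound 4 `COc1ccc(C2=NN(c3ccc(-c4ccccc4)nn3)C(c3ccc(OC)cc3OC)C2)cc1` differs from compound 3 by methoxy in place of hydrogen on an aromatic carbon. Among the compounds with values here, the one measured step of the same kind, from compound 2 to compound 3, gave no readable size, so the data offer no direction and no magnitude for this change. What is expected for compound 4 is therefore that it stays at the limit, an estimated 150000 nM with a range from 40000 nM to 600000 nM. The step that the limit leaves unreadable from compound 3 to compound 4 is expected to be nil within scatter.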

Compound 4, half-maximal inhibitory concentration: > 100000 nM
Compound 4: only a limit was reported; the forecaster's own chance of this, stated with the estimate: 85%; the middle value does not contradict the limit.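

No step from compound 1, compound 2 or compound 3 to compound 4 can be read, because each value is a limit and not a number: the limit of > 100000 nM in this assay, at which 4 of the 4 values shown sit.

The compounds shown leave open how strongly, if at all, any of them inhibits these cells, and whether adding a methoxy group changes that.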